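A Second Fluorine on the Phenoxy Ring

The source may report more compounds than this note shows. Statements on the series, on what has been measured and on what is new or still open speak of the compounds shown alone.

The measured compounds:
compound 1, `CC(C)[C@H](NC(=O)COc1cccc2ccccc12)C(=O)N[C@@H](CC(=O)O)C(=O)COc1ccccc1`: 11200 nM
compound 2, `CC(C)[C@H](NC(=O)COc1cccc2ccccc12)C(=O)N[C@@H](CC(=O)O)C(=O)COc1ccccc1C(F)(F)F`: 17300 nM
compound 3, `CC(C)[C@H](NC(=O)COc1cccc2ccccc12)C(=O)N[C@@H](CC(=O)O)C(=O)COc1ccc(F)cc1`: 14300 nM

In a functional assay with Homo sapiens as the target (a higher number here means a weaker inhibitor, a lower number a stronger inhibitor), compound 1 has the lowest of the three numbers, but neither of its neighbours is separated from it beyond the scatter: a 1.3-fold higher number from compound 1 to compound 3 (0.11 log units; within the scatter) and a 1.5-fold higher number from compound 1 to compound 2 (0.19 log units; within the scatter). The three compounds therefore cannot be placed in any order on these numbers.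

Compound 4, `CC(C)[C@H](NC(=O)COc1cccc2ccccc12)C(=O)N[C@@H](CC(=O)O)C(=O)COc1ccc(F)c(F)c1`, is the next step from compound 1, with 3,4-difluorophenyl in place of phenyl on an oxygen on a saturated carbon. For the measured compounds named here, the step that bears most directly on it is the one from compound 1 to compound 3, where a single fluoro in place of hydrogen on the same ring left the number essentially unchanged, a 1.3-fold higher number from compound 1 to compound 3 (0.11 log units; within the scatter). The step of a 1.5-fold higher number from compound 1 to compound 2 (0.19 log units; within the scatter), a bulkier substituent on the same ring, also stayed within the scatter. Adding a second fluoro is thus expected to give at most a small shift, a 1.3-fold higher number from compound 1 to compound 4 (0.10 log units; within the scatter), with no direction beyond the scatter claimed. Compound 4 is estimated at 14000 nM, in the range 6500 nM to 30000 nM.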

Compound 4, half-maximal inhibitory concentration: 16200 nM
The estimate for compound 4 lay 1.2-fold (0.06 log units) below the measured number, and the stated range covers the measured number.
By their numbers in this assay, from the lowest: compounds 1, 3, 4 and 2 (each within the scatter of the next).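

In this assay, the ring on this oxygen now carries two fluoro groups, and 3,4-difluorophenyl in place of phenyl gave a 1.4-fold higher number from compound 1 to compound 4 (0.16 log units; within the scatter) while the second fluoro on the ring of compound 3 gave a 1.1-fold higher number from compound 3 to compound 4 (0.05 log units; within the scatter), so neither one fluoro nor two moved the number beyond the scatter. Set against the 2-(trifluoromethyl)phenyl group, the same ring gave a 1.1-fold lower number from compound 2 to compound 4 (0.03 log units; within the scatter), which leaves all four aryl groups on this oxygen within the scatter of one another. Nothing available here explains why these numbers stay so close.

The compounds shown carry only fluoro and trifluoromethyl on this ring. From the compounds shown here alone, whether an amine, a carboxylic acid or a longer chain on the ring would move the number beyond the scatter remains open.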